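Amide exchange at the carbonyl of the shared core

The source may hold more compounds than are shown below. What is called first, only, known or untested is meant among the compounds shown, and "the series" means these compounds.

Measured so far:
compound 1 `N#CCNC(=O)[C@@H]1C[C@@H](S(=O)(=O)c2ccccc2C(F)(F)F)C[C@H]1C(=O)N1CCOCC1`, 0.9 nM
compound 2 `N#CC1(NC(=O)[C@@H]2C[C@@H](S(=O)(=O)c3ccccc3)C[C@H]2C(=O)N2CCOCC2)CCC1`, 4 nM
compound 3 `N#CC1(NC(=O)[C@@H]2C[C@@H](S(=O)(=O)c3ccccc3)C[C@H]2C(=O)N2CC3(COC3)C2)CC1`, 3 nM

All three were read in an assay on isolated protein for inhibition of cathepsin S (Homo sapiens), read by fluorescence, with a stated time of 20 min; a lower number here means a stronger inhibitor, a higher number a weaker inhibitor. Compound 3 stands second highest of the three numbers; its nearest neighbour is compound 2, within the scatter, and its furthest is compound 1, which sits beyond the scatter with the lower number. Compound 4 `N#CC1(NC(=O)[C@@H]2C[C@@H](S(=O)(=O)c3ccccc3)C[C@H]2C(=O)N2CCCC2)CC1` is not yet measured. It differs from compound 3 in one place: a group of 5 heavy atoms (4 carbon, 1 nitrogen; one five-membered non-aromatic ring with 1 hetero atom) in place of a group of 7 heavy atoms (5 carbon, 1 nitrogen, 1 oxygen; 2 four-membered non-aromatic rings with 1 hetero atom each), on a carbonyl carbon. For the measured compounds named here, no step between two measured compounds isolates this exchange, so the expectation rests on compound 3 alone. Because compound 2, carrying a different amide, gives 4 nM close to compound 3, an amide exchange of this kind is expected to move the number little. The step is expected to be no change at the digits printed from compound 3 to compound 4 (within the scatter), none beyond the scatter. Compound 4 is therefore estimated at 3 nM, within 1 nM to 10 nM.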

Compound 4, half-maximal inhibitory concentration: 2 nM
Compound 4: the middle estimate sits 1.5-fold (0.18 log units) above what was measured; low and high end bracket the measured number.
By their numbers in this assay, from the lowest: compound 1; then compounds 4, 3 and 2 (each within the scatter of the next).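

At the carbonyl carbon, a direct reading of this exchange is now available: in this assay, pyrrolidin-1-yl in place of the group with two four-membered rings gives a 1.5-fold lower number from compound 3 to compound 4 (0.18 log units; within the scatter). Here, losing the ring oxygen and its hydrogen-bond acceptor leaves no difference beyond the scatter. No available evidence bears on this result.

Open, on these data alone, is whether a piperazin-1-yl group or an open-chain diethylamino group on the same carbonyl carbon would stay within the scatter of compound 4. Also open, as far as these compounds go, is whether pyrrolidin-1-yl reads the same on the trifluoromethyl-bearing compound 1.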